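Cyclobutyl amine variation on the nitrile-bearing core

The compounds below may be only part of what the source reports. "The series", "measured", "known", "first", "only" and "open" are said of these compounds alone.

Three compounds have numbers in an assay on isolated protein for inhibition of protein kinase C theta type (Homo sapiens), read by TR-FRET, with a stated time of 2 h; a higher number here means a weaker inhibitor, a lower number a stronger inhibitor. Compound 1 `N#Cc1cnc(NCc2cnccc2C(F)(F)F)cc1NC[C@H]1C[C@H](O)C1` gives 700 nM and stands second highest of the three. Compound 2 `N#Cc1cnc(NCc2ccccc2)cc1N[C@H]1CC[C@@H](O)CC1` gives 7000 nM, a weaker inhibitor than compound 1 by a margin beyond the scatter. Compound 3 `CC1(C)C[C@H](Nc2nc(NCc3cnccc3C(F)(F)F)ncc2C#N)CC[C@@H]1O`, built on a different core, gives 6 nM and is the strongest of the set. Among the compounds with values here, no step between measured compounds that differ in one place is available.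

Compound 4 `CC1(C)[C@@H](Nc2cc(NCc3cnccc3C(F)(F)F)ncc2C#N)C[C@H]1C(N)=O` changes compound 1 at the amine side chain: 3-carbamoyl-2,2-dimethylcyclobutyl in place of (3-hydroxycyclobutyl)methyl on a nitrogen on an aromatic ring. The change moves the ring onto the nitrogen and adds the carbamoyl and the two methyls. A moderate step toward a stronger inhibitor is expected, a 4.7-fold lower number from compound 1 to compound 4 (0.67 log units; beyond the scatter), without a directly comparable pair to anchor it. For compound 4 in this assay the estimate is 150 nM, within 30 nM to 1000 nM.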

Compound 4, half-maximal inhibitory concentration: 140 nM
Beside the measured number, compound 4's estimate is 1.1-fold (0.03 log units) above it, and the stated range covers the measured number.
By their numbers in this assay, from the lowest: compound 3; then compound 4; then compound 1; then compound 2.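

Within the data shown here, the side chain on the nitrogen on an aromatic ring tolerates substantial change: 3-carbamoyl-2,2-dimethylcyclobutyl in place of (3-hydroxycyclobutyl)methyl gives a 5.0-fold lower number from compound 1 to compound 4 (0.70 log units; beyond the scatter) in this assay as the only one-place comparison so far. Compound 4 carries no hydroxyl, so a hydroxyl is not required for this gain on the core of compound 1. Nothing measured accounts for the step. The carbamoyl, the two methyls and the shift of the ring onto the nitrogen remain unseparated. A plain 3-carbamoylcyclobutyl or a 3-carboxycyclobutyl on the same nitrogen would begin to divide them.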